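The source may hold more compounds than are shown below. What is called first, only, known or untested is meant among the compounds shown, and "the series" means these compounds.

Measured compounds:
- compound 1, `COc1ccc(/C=C/C(=O)Nc2ccc3ncnc(Nc4cccc(Br)c4)c3c2)cc1`: 3.36 ug/mL
- compound 2, `O=C(/C=C/c1ccc(Cl)cc1)Nc1ccc2ncnc(Nc3cccc(Cl)c3)c2c1`: 12.4 ug/mL

Both compounds share a core that carries an acrylamide on one side and an aniline on the other. In a functional assay on A549 cells (Homo sapiens) for antiproliferative activity, read by MTT assay, with a stated time of 48 h (on this read-out lower numbers stand for stronger inhibition and higher numbers for weaker inhibition), compound 1 gives 3.36 ug/mL, and compound 2 gives 12.4 ug/mL. Compound 2 thus has the higher of the two numbers, and the gap to compound 1 lies beyond the usual scatter of this assay; since the two compounds differ in more than one place, nothing more can be read from that comparison.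

Compound 3, `O=C(/C=C/c1cccs1)Nc1ccc2ncnc(Nc3cccc(Cl)c3)c2c1`, differs from compound 2 in a single place: thiophen-2-yl in place of 4-chlorophenyl on a double-bonded chain carbon bound to a double-bonded chain carbon. The aniline side and the core are unchanged. Going by the values given here, no measured pair shows what swapping a six-membered aromatic ring for a five-membered one at this end does, so there is no direct basis for predicting a shift in either direction.

For that reason the number for compound 3 in this assay is expected to stay close to that of compound 2, with the estimated step of a 1.4-fold lower number from compound 2 to compound 3 (0.14 log units; within the scatter) lying within the scatter. The estimate for compound 3 is 9 ug/mL, in a range from 3 ug/mL to 27 ug/mL.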

Compound 3, half-maximal inhibitory concentration: 9.23 ug/mL
Compound 3: middle estimate off by 1.0-fold (0.01 log units), on the low side; the measured number falls inside the stated range.
By their numbers in this assay, from the lowest: compound 1; then compounds 3 and 2 (each within the scatter of the next).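

In this assay, thiophen-2-yl in place of 4-chlorophenyl on a double-bonded chain carbon bound to a double-bonded chain carbon gives a 1.3-fold lower number from compound 2 to compound 3 (0.13 log units; within the scatter), so the two compounds cannot be told apart on this read-out. This is the first pair shown that differs in one place, and it indicates that, in this pair, a six-membered aromatic ring of carbon only can give way to a five-membered aromatic ring with 1 hetero atom, with the chlorine gone as well, without a shift beyond the usual scatter. Nothing measured here bears on why the two compounds read alike.

As far as these compounds go, it remains open whether this position would accept something other than an aromatic ring, such as an amine or a carboxylic acid, as readily as it accepts these two rings. From the compounds shown here alone, compound 1 differs from compound 3 in more than one place, so it also remains open whether the same swap would read alike with the bromine-bearing aniline of compound 1.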